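Trading a ring for a chain: clearance in question

A few compounds are considered here, and "the series" means these few. Any claim that something is new, unique, unknown or untested is made for them only; others in the source may bear on it.

Among the compounds with values here, only one number is available so far in an in vitro ADME assay on microsomes from liver (Homo sapiens) for metabolic stability, tested at 0.2 uM; on this read-out higher numbers stand for fast clearance and lower numbers for slow clearance. For compound 1 `CC(C)c1c(COc2cccc(OCC3CCOCC3)c2)[nH]c2ccccc2c1=O`, the entry in this assay reads "not determined" (no result reported), so it offers no comparison. Compound 2 `Cc1c(COc2cc(OCC3CCOCC3)ccn2)[nH]c2ccccc2c1=O` gives 113 mL/min/kg, and with no second number beside it, this value cannot yet be ranked against another compound.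

Compound 3 `Cc1c(COc2cc(OCCC(C)(C)O)ccn2)[nH]c2ccccc2c1=O` keeps the core of compound 2 and alters a single side chain: 2-hydroxy-2-methylpropyl in place of oxan-4-yl on a saturated chain carbon bound to an oxygen on an aromatic ring. Put simply, 2-hydroxy-2-methylpropyl stands in place of oxan-4-yl on a saturated chain carbon bound to an oxygen on an aromatic ring, turning (oxan-4-yl)methoxy into 3-hydroxy-3-methylbutoxy.

Within the data shown here, no measured pair of compounds shows what such a swap does, so any forecast here is loose, and compound 2 at 113 mL/min/kg is the only anchor. The expected change is a 1.4-fold lower number from compound 2 to compound 3 (0.15 log units; within the scatter), a small fall that stays within the usual scatter of repeat measurements. In this assay, the estimated value for compound 3 is 80 mL/min/kg, with an expected range from 40 mL/min/kg to 140 mL/min/kg.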

Compound 3, clearance in the Homo sapiens assay: 38 mL/min/kg
Estimate against measurement, compound 3: 2.1-fold (0.32 log units) above; the measured number lies below the stated range.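

Within the data shown here, putting 2-hydroxy-2-methylpropyl in place of oxan-4-yl on this saturated chain carbon gives the first step that can be read at this position: in the Homo sapiens assay there is a 3.0-fold lower number from compound 2 to compound 3 (0.47 log units; beyond the scatter), and this step lies beyond the usual scatter. A lower number here means slower clearance, so the ring of compound 2 is not required for this read-out, since compound 3 has no ring in this side chain and still gives the better number. The change does not trade one read-out for the other, as the number in a physicochemical assay for solubility, at pH 6.8 (on this read-out lower numbers stand for lower solubility and higher numbers for higher solubility), moves up at the same time, and higher is the better direction there: the measured solubility of compound 2, 36000 nM, and of compound 3, 85000 nM, a 2.4-fold higher number (0.37 log units; beyond the scatter) In the physicochemical assay compound 2 gives 36000 nM and compound 3 gives 85000 nM.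

The change removes a ring and adds a hydrogen-bond donor in a single move, so this one pair cannot tell which of the two goes with the lower clearance and the higher solubility. A plain 3-methylbutyl chain without the hydroxyl, or an amine or a carboxylic acid at the end of the same chain, would begin to separate those two parts of the change.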